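The compounds below may be only part of what the source reports. "The series", "measured", "known", "first", "only" and "open" are said of these compounds alone.

Compound 1, `NCCNc1cc(N2CCN(S(=O)(=O)c3ccccc3)CC2)nc2ccccc12`, gives 20500 nM in an ADME assay on HEp-2 cells (Homo sapiens) for cytotoxicity, read by CCK-8 assay, with a stated time of 6 days; a higher number here means that more compound is tolerated, a lower number that less compound is tolerated.
Compound 2, `NCCNc1cc(N2CCN(C(=O)C3(c4ccccc4)CCCC3)CC2)nc2ccccc12`, reaches only a limit of the assay in this assay, namely > 100000 nM.
Compound 3, `NCCNc1cc(N2CCN(C(=O)C3(c4ccccc4)CC3)CC2)nc2ccccc12`, likewise reaches only a limit of the assay in this assay, namely > 100000 nM.

Compound 3 therefore stands at the top of what this assay can report: its value is a limit, not a number, and the same holds for compound 2, as the limit of > 100000 nM in this assay, at which 2 of the 3 values shown sit, records. Only compound 1 gives a measured number, and it lies well below that limit. For the measured compounds named here, the one step between measured neighbours, a step that the two limits leave unreadable from compound 2 to compound 3, cannot be read because both of its ends are limits.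

Compound 4, `NCCNc1cc(N2CCN(C(=O)C3CCCCC3)CC2)nc2ccccc12`, is not yet measured. It differs from compound 3 by cyclohexyl in place of 1-phenylcyclopropyl on a carbonyl carbon. Going by the values given here, the only step that bears on a change at this carbonyl carbon is the unreadable one from compound 2 to compound 3, so no size can be taken from it; what the data show is that both amide-type neighbours of compound 3 sit at the limit. On that basis compound 4 is expected to sit at or near the same limit, with a number no higher from compound 3 to compound 4 (the limit leaves the size open) being an expected step of no size beyond the scatter. The estimate for compound 4 is 100000 nM, between 40000 nM and 300000 nM.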

Compound 4, half-maximal cytotoxic concentration: > 100000 nM
Compound 4: only a limit was reported; the forecaster's own chance of this, stated with the estimate: 60%; the middle value sits exactly at the limit.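

In this assay, cyclohexyl on this carbonyl carbon, which has no aromatic ring, leaves compound 4 at the assay limit, as 1-phenylcyclopropyl does in compound 3 and 1-phenylcyclopentyl in compound 2, so the steps among these three compounds cannot be read. On these data alone, the exchange of phenylsulfonyl for cyclohexylcarbonyl on an amine nitrogen in a ring gives an at least 4.8-fold higher number from compound 1 to compound 4 (0.68 log units; beyond the scatter), a second compound with a carbonyl group at this nitrogen now contrasted with the sulfonyl compound, and the true size of the step stays open with compound 4 at a limit. All three carbonyl compounds shown now share this ceiling, compound 1 being the one compound that goes against the pattern, and the record reads: the limit of > 100000 nM in this assay, at which 3 of the 4 values shown sit.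

As far as these compounds go, how far compound 2, compound 3 and compound 4 lie beyond the limit remains unknown, so no order among the three groups on the carbonyl carbon can be given. Also open, from the compounds shown here alone, is whether the difference from compound 1 follows the sulfonyl link or the phenyl group on it, which a cyclohexylsulfonyl group on the same nitrogen would separate, and whether an amine or a longer chain on the carbonyl carbon would stay at the limit.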